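Ring-nitrogen substituents on the shared core: compound 4

A few compounds are considered here, and "the series" means these few. Any claim that something is new, unique, unknown or untested is made for them only; others in the source may bear on it.

Compound 1 `CCCn1c(=O)[nH]c2nc(-c3ccc(S(=O)(=O)N4CCN(c5ccc(Br)cc5)CC4)cc3)[nH]c2c1=O`: in an assay on CHO cells for displacement of a labelled ligand from adenosine receptor A3 (Homo sapiens), read by scintillation counting, with a stated time of 45 min, in the presence of a further agent that is not named here (on this read-out higher numbers stand for weaker inhibition and lower numbers for stronger inhibition), compound 1 gives > 1000 nM, a limit of the assay.
Compound 2 `CCCn1c(=O)[nH]c2nc(-c3ccc(S(=O)(=O)N4CCN(c5ccccc5C)CC4)cc3)[nH]c2c1=O`: in this assay compound 2 gives > 1000 nM, a limit of the assay.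
Compound 3 `CCCn1c(=O)[nH]c2nc(-c3ccc(S(=O)(=O)N4CCN(C)CC4)cc3)[nH]c2c1=O`: in this assay compound 3 gives > 1000 nM, a limit of the assay.

Compound 3 stands only at a limit, and the two other values shown are limits as well; all three sit at the limit of > 1000 nM in this assay, at which 3 of the 3 values shown sit. The steps among the measured compounds, a step that the two limits leave unreadable from compound 1 to compound 2, a step that the two limits leave unreadable from compound 1 to compound 3 and a step that the two limits leave unreadable from compound 2 to compound 3, therefore cannot be read in size or direction.

Compound 4 is `CCCn1c(=O)[nH]c2nc(-c3ccc(S(=O)(=O)N4CCN(c5ccccc5F)CC4)cc3)[nH]c2c1=O`. The change from compound 3 is 2-fluorophenyl in place of methyl on an amine nitrogen in a ring. Within the data shown here, the steps that bear on it are those exchanging methyl for an aryl group on the same ring nitrogen, read in reverse, from compound 3 to compound 1 and from compound 3 to compound 2; both are unreadable, and no step in this set has yet left the limit.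

For compound 4 no readable step beyond the scatter is expected, a step that the limit leaves unreadable from compound 3 to compound 4, with the value most likely reported again as a limit. Compound 4 is estimated at 3000 nM, in the range 1000 nM to 10000 nM.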

Compound 4, inhibition constant: > 1000 nM
Compound 4: no number, only a limit; the forecaster's own chance of this, stated with the estimate: 85%; the middle value lies beyond the limit too.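

In this assay compound 4 gives > 1000 nM, a limit of the assay. The steps to compound 4 from compound 1, compound 2 and compound 3 cannot be read in size or direction, as all four compounds share one limit: the limit of > 1000 nM in this assay, at which 4 of the 4 values shown sit.

The compounds shown leave open whether any substituent on this ring nitrogen gives a measurable inhibition constant, and how these four compare.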